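The compounds below may be only part of what the source reports. "The series", "measured", "known", "first", "only" and "open" are said of these compounds alone.

Compound 2 `CSc1ccc(Cc2ccc3ccccc3c2O)cc1` stands lowest of the two numbers recorded so far in an assay on RBL-1 cells with Polyunsaturated fatty acid 5-lipoxygenase (Rattus norvegicus) as the target (on this read-out higher numbers stand for weaker inhibition and lower numbers for stronger inhibition), where compound 2 gives 48 nM. Among the measured compounds shown here, its only neighbour is compound 1 `Oc1c(Cc2ccc(OCc3ccccc3)cc2)ccc2ccccc12`, which in this assay gives 72 nM. For the measured compounds named here, the single measured step, a 1.5-fold lower number from compound 1 to compound 2 (0.18 log units; within the scatter), lies within the scatter, so the two compounds cannot be separated on these numbers.

Compound 3 `CN(C)c1ccc(Cc2ccc3ccccc3c2O)cc1` carries a different group at the same place: dimethylamino in place of methylsulfanyl on an aromatic carbon. Going by the values given here, no measured step covers this exchange directly. Among the compounds with values here, the only step available, a 1.5-fold lower number from compound 1 to compound 2 (0.18 log units; within the scatter), concerns a different exchange at that aromatic carbon and stayed within the scatter, which is the sole guide to how far this position tolerates change. Compound 3 is therefore expected to land close to compound 2, with no step beyond the scatter in this assay. The step from compound 2 to compound 3 is estimated as a 1.3-fold higher number from compound 2 to compound 3 (0.10 log units; within the scatter). Within the data shown here, compound 3 is expected to give 60 nM, within a range from 20 nM to 200 nM, the width reflecting that no measured step matches the exchange.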

Compound 3, half-maximal inhibitory concentration: 140 nM
Estimate against measurement, compound 3: 2.3-fold (0.37 log units) below, and the stated range covers the measured number.
By their numbers in this assay, from the lowest: compounds 2, 1 and 3 (each within the scatter of the next, the first and the last beyond it).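

In this assay, the exchange of methylsulfanyl for dimethylamino gives a 2.9-fold higher number from compound 2 to compound 3 (0.46 log units; beyond the scatter), a modest step, but the first at this aromatic carbon to pass beyond the scatter, so this position does not accept every group without a measurable shift. Among the compounds shown here, the exchange of benzyloxy for dimethylamino gives a 1.9-fold higher number from compound 1 to compound 3 (0.29 log units; within the scatter), which stays within the scatter, so compounds 1 and 3 cannot be separated, and only the pair of compound 2 and compound 3 stands apart on these numbers. No measurement is available that would explain the step from methylsulfanyl to dimethylamino.

With only three groups at this aromatic carbon, the compounds shown leave open whether a methoxy group, a primary amine or a carboxylic acid would stay within the scatter of compound 2 or would give a larger step. All three compounds also share the same core, so they leave open how the numbers in this assay would respond to a change anywhere else in the structure.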